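Hydroxy added to the phenyl ring of compound 3

The compounds below may be only part of what the source reports. "The series", "measured", "known", "first", "only" and "open" are said of these compounds alone.

In an assay on isolated protein for inhibition of Maltase-glucoamylase (Homo sapiens), with a stated time of 15 min (a lower number here means a stronger inhibitor, a higher number a weaker inhibitor), compound 1 `O=C(N/N=C/c1ccc(O)cc1O)c1ccc(-c2nc3ccccc3s2)cc1` gives 5580 nM, while compound 2 `COc1ccc(/C=N/NC(=O)c2ccc(-c3nc4ccccc4s3)cc2)cc1OC` is reported as "not active" (no number reported) without a number. Within the data shown here, compound 3 `O=C(N/N=C/c1ccccc1)c1ccc(-c2nc3ccccc3s2)cc1` gives 8050 nM, the higher of the two numbers at hand, and the step of a 1.4-fold higher number from compound 1 to compound 3 (0.16 log units; within the scatter) is the only single-point comparison available. Compound 4 `O=C(N/N=C/c1cccc(O)c1)c1ccc(-c2nc3ccccc3s2)cc1` differs from compound 3 by hydroxy in place of hydrogen on an aromatic carbon. That one step bears on this change, since it also alters the hydroxy substitution on the same ring, and it stayed within the scatter, so for compound 4 no step beyond the scatter is expected in this assay. Compound 4 is therefore estimated at 6500 nM, with a range from 3000 nM to 14000 nM. The expected step of a 1.2-fold lower number from compound 3 to compound 4 (0.09 log units; within the scatter) is thus essentially flat.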

Compound 4, half-maximal inhibitory concentration: 9210 nM
Estimate against measurement, compound 4: 1.4-fold (0.15 log units) below, and the stated range covers the measured number.
By their numbers in this assay, from the lowest: compounds 1, 3 and 4 (each within the scatter of the next).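

Hydroxy on this aromatic carbon, meta to a large group, brings a 1.1-fold higher number from compound 3 to compound 4 (0.06 log units; within the scatter) in this assay and so leaves the number within the scatter. Putting 3-hydroxyphenyl in place of 2,4-dihydroxyphenyl brings a 1.7-fold higher number from compound 1 to compound 4 (0.22 log units; within the scatter) and stays within the scatter as well, so compound 1, compound 3 and compound 4 cannot be told apart here. No evidence at hand bears on this result. On these data alone, whether an amine or a carboxylic acid on this same carbon would move the number beyond the scatter remains open.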